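Thiophene enone in place of formyl on a quinoline core

This account rests on a few compounds, and the source may have more. Where it says the series, first, only, none or still open, it means among the compounds named here.

Compound 1 `COc1ccc(-c2cc3ccccc3nc2C=O)cc1` gives > 10000 nM in a functional assay on MDA-MB-231 cells (Homo sapiens) for antiproliferative activity, read by XTT assay, with a stated time of 72 h; on this read-out higher numbers stand for weaker inhibition and lower numbers for stronger inhibition; this is a limit of the assay, not a number.
Compound 2 `COc1ccc(-c2cc3ccccc3nc2/C=C/C(=O)c2ccc(O)cc2)cc1` gives 6350 nM in this assay.
Compound 3 `COc1ccc(-c2cc3ccccc3nc2/C=C/C(=O)c2ccc(N)cc2)cc1` gives 7510 nM in this assay.

Compound 1 stands only at the limit of > 10000 nM in this assay, at which 1 of the 3 values shown sits, so its true value is not known. Among the measured compounds shown here, compounds 2 and 3, which share the core of compound 1, give measurable numbers, and the single measured step between them, a 1.2-fold higher number from compound 2 to compound 3 (0.07 log units; within the scatter), lies within the scatter. Compound 4 `COc1ccc(-c2cc3ccccc3nc2/C=C/C(=O)c2cccs2)cc1` differs from compound 1 by 2-((thiophen-2-yl)carbonyl)ethenyl in place of formyl on an aromatic carbon. For the measured compounds named here, no measured step covers this exact change, so the expectation rests on compounds 2 and 3 alone. A step of an at least 1.4-fold lower number from compound 1 to compound 4 (0.15 log units; that floor lies within the scatter) is expected, bringing compound 4 into the range where numbers are reported. Compound 4 is estimated at 7000 nM, with a range from 2500 nM to 20000 nM.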

Compound 4, half-maximal inhibitory concentration: 410 nM
Estimate against measurement, compound 4: 17-fold (1.23 log units) above; measured number outside the range, below it.
By their numbers in this assay, from the lowest: compound 4; then compounds 2 and 3 (each within the scatter of the next). At a limit, above all of these: compound 1.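

Changing only the ring on the carbonyl carbon moves the number far more than the earlier hydroxy-to-amino swap did: thiophen-2-yl in place of 4-hydroxyphenyl gives a 15-fold lower number from compound 2 to compound 4 (1.19 log units; beyond the scatter), and thiophen-2-yl in place of 4-aminophenyl gives an 18-fold lower number from compound 3 to compound 4 (1.26 log units; beyond the scatter). So the group at this end of the enone can strongly change antiproliferative activity on this core. The full replacement of formyl gives an at least 24-fold lower number from compound 1 to compound 4 (1.38 log units; beyond the scatter), a step that is only a floor, since compound 1 has a limit and not a number: the limit of > 10000 nM in this assay, at which 1 of the 4 values shown sits.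

Whether this gain is specific to thiophene stays open, as the compounds shown include no unsubstituted phenyl, furan-2-yl or thiophen-3-yl on the carbonyl carbon.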